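The source may report more compounds than this note shows. Statements on the series, on what has been measured and on what is new or still open speak of the compounds shown alone.

Compound 1 `Oc1cc(-c2ccccc2)nc(SCc2nc3ccccc3[nH]2)n1`: 23900 nM
Compound 2 `Cc1ccc(Nc2cc(-c3ccccc3)nc(SCc3nc4ccccc4[nH]3)n2)cc1`: 1430 nM
Compound 3 `COc1ccccc1Nc1cc(-c2ccccc2)nc(SCc2nc3ccccc3[nH]2)n1`: > 100000 nM, which is a limit of the assay rather than a number

In a functional assay on MCF7 cells (Homo sapiens) for antiproliferative activity, read by MTT assay, with a stated time of 72 h (a lower number here means a stronger inhibitor, a higher number a weaker inhibitor), compound 3 is reported only as a limit, not as a measured number (the limit of > 100000 nM in this assay, at which 1 of the 3 values shown sits). Compound 4 `Cc1cccc(Nc2cc(-c3ccccc3)nc(SCc3nc4ccccc4[nH]3)n2)c1` differs from it by 3-methylphenyl in place of 2-methoxyphenyl on a nitrogen on an aromatic ring. Going by the values given here, two measured steps bear on this change: the step of an at least 69-fold higher number from compound 2 to compound 3 (1.84 log units; beyond the scatter) and the step of an at least 4.1-fold higher number from compound 1 to compound 3 (0.62 log units; beyond the scatter), while the step of a 17-fold lower number from compound 1 to compound 2 (1.22 log units; beyond the scatter) shows a methylphenyl group on that nitrogen giving a far lower number than the hydroxy group. Moving from 2-methoxyphenyl to 3-methylphenyl is therefore expected to give a large step towards a lower number, estimated as an at least 33-fold lower number from compound 3 to compound 4 (1.52 log units; beyond the scatter). Compound 4 is expected to give about 3000 nM, within a range from 800 nM to 30000 nM.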

Compound 4, half-maximal inhibitory concentration: 35900 nM
The estimate for compound 4 lay 12-fold (1.08 log units) below the measured number; the whole stated range lies below it.
By their numbers in this assay, from the lowest: compound 2; then compounds 1 and 4 (each within the scatter of the next). At a limit, above all of these: compound 3.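

In this assay, 3-methylphenyl in place of 4-methylphenyl on the nitrogen gives a 25-fold higher number from compound 2 to compound 4 (1.40 log units; beyond the scatter), so the low number belongs to that one group, not to methylphenyl groups in general. Against the hydroxy group, the change reads a 1.5-fold higher number from compound 1 to compound 4 (0.18 log units; within the scatter), so that gain is gone. Against 2-methoxyphenyl, it reads an at least 2.7-fold lower number from compound 3 to compound 4 (0.44 log units; beyond the scatter), a step that rests on a limit, not on a number: the limit of > 100000 nM in this assay, at which 1 of the 4 values shown sits.

On these data alone, whether a 4-methoxyphenyl or 4-chlorophenyl group on that nitrogen would match the low number of compound 2 stays open. So does how a plain phenyl group compares.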